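The compounds below may be only part of what the source reports. "The series", "measured", "known", "first", "only" and "open" are said of these compounds alone.

Of the compounds shown here, two have been tested so far. Compound 1 `Cc1nnc(NC(N)=O)cc1Cc1ccccc1` gives 28 mg/kg in a functional assay on the whole organism (Leg) with Mus musculus as the target, at a dose of 0.96 mg/kg by the subcutaneous route; on this read-out higher numbers stand for an effect only at larger amounts of compound and lower numbers for an effect already at smaller amounts. Compound 2 `Cc1nn2cnnc2cc1Cc1ccccc1` gives 85 mg/kg in this assay, the highest of the two numbers; the gap to compound 1 lies beyond the scatter, so compound 2 needs the larger amount.

The step under consideration leads to compound 3 `Cc1nn2c(N)nnc2cc1Cc1ccccc1`. Relative to compound 2 the change is amino in place of hydrogen on an aromatic carbon; in words, amino in place of hydrogen on an aromatic carbon. For the measured compounds named here, no measured pair differs in this one place, so the size of the step has no precedent here and can only be expected. Compound 1 carries an amino within its side chain and gives the lower number, which leaves room for a moderate gain; the change itself is small.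

For compound 3 the expected step is a 1.7-fold lower number from compound 2 to compound 3 (0.23 log units; within the scatter), a decrease in the dose that is expected to be modest and possibly within the scatter. Compound 3 is therefore estimated at 50 mg/kg in this assay, with a range from 18 mg/kg to 140 mg/kg.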

Compound 3, dose for half-maximal effect: 35 mg/kg
Estimate against measurement, compound 3: 1.4-fold (0.15 log units) above; the range from low to high includes it.
By their numbers in this assay, from the lowest: compounds 1 and 3 (each within the scatter of the next); then compound 2.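

For the compounds shown here, on the aromatic carbon of the five-membered aromatic ring with 3 nitrogen, between two ring nitrogen atoms, amino in place of hydrogen gives the first step that can be read at this position in this assay: a 2.4-fold lower number from compound 2 to compound 3 (0.39 log units; beyond the scatter). This position therefore responds to substitution: a single entering heavy atom, a nitrogen, moves the number beyond the scatter, and it moves towards an effect at smaller amounts of compound. The size of this step is a single observation on one core, and nothing at hand accounts for it.

Whether this step is specific to amino remains open, since hydrogen and amino are the only two groups shown at this carbon; methylamino, dimethylamino, hydroxyl or methyl in the same place would show whether the number follows the nitrogen, its hydrogens, or simply the presence of any group there. From the compounds shown here alone, it is also open whether a longer chain on the amino nitrogen would extend the step or reverse it, and whether the step would keep its size on a core changed elsewhere.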